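A few compounds are considered here, and "the series" means these few. Any claim that something is new, unique, unknown or untested is made for them only; others in the source may bear on it.

Compound 1 `COc1cc(-c2nnc(SCC(=O)c3ccc(F)c(F)c3)n2N)cc(OC)c1OC` and compound 2 `COc1cc(-c2nnc(SCC(=O)Nc3ccccc3F)n2N)cc(OC)c1OC` share one core and differ only at the carbonyl carbon of the thioether arm. In a functional assay on PC-3 cells (Homo sapiens) for antiproliferative activity, read by MTT assay, with a stated time of 48 h (a higher number here means a weaker inhibitor, a lower number a stronger inhibitor), compound 1 reaches only > 100000 nM, which is a limit of the assay and not a number. In this assay, within the data shown here, compound 2 gives 36700 nM, the only value of the set reported as a number. The change from compound 1 to compound 2 puts (2-fluorophenyl)amino in place of 3,4-difluorophenyl on the carbonyl carbon, and it brings an at least 2.7-fold lower number from compound 1 to compound 2 (0.43 log units; beyond the scatter); this step rests on (the limit of > 100000 nM in this assay, at which 1 of the 2 values shown sits), so its true size is open.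

Compound 3 `COc1cc(-c2nnc(SCC(=O)NCc3ccc(Cl)cc3)n2N)cc(OC)c1OC` differs from compound 2 by 4-chlorobenzyl in place of 2-fluorophenyl on an amide-type nitrogen. Among the measured compounds shown here, the one measured step altered the atom attached to the carbonyl carbon, whereas this change keeps the amide-type nitrogen and only exchanges the group on it; no measured pair isolates a change of that kind. Compound 3 is therefore expected to lie close to compound 2, with a 1.2-fold lower number from compound 2 to compound 3 (0.09 log units; within the scatter) as the estimated step. The estimated value for compound 3 in this assay is 30000 nM, expected between 9000 nM and 100000 nM.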

Compound 3, half-maximal inhibitory concentration: > 100000 nM
Compound 3 was reported as a limit; the forecaster's own chance of this, stated with the estimate: 25%; middle value at least 3.3-fold (0.52 log units) from the limit.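

Keeping the amide-type nitrogen does not by itself preserve the response in this assay: exchanging only the group on that nitrogen, with 4-chlorobenzyl in place of 2-fluorophenyl, gives an at least 2.7-fold higher number from compound 2 to compound 3 (0.43 log units; beyond the scatter). The earlier step altered the atom attached to the carbonyl carbon, so it could not show that the group carried on this nitrogen also changes the read-out. Compound 3 gives > 100000 nM, which is a limit of the assay and not a number, so the direction of this step can be read but its true size is open, and the step between the two limit compounds cannot be read at all: the limit of > 100000 nM in this assay, at which 2 of the 3 values shown sit.

The exchange alters both the link to the ring and the halogen, so the compounds shown do not separate the benzyl link from the change of fluorine to chlorine or from the different place of the halogen. From the compounds shown here alone, how a 2-fluorobenzyl, an unsubstituted benzyl or a longer chain on the same nitrogen would read in this assay remains open, as does whether any group here would give a markedly lower number than compound 2 does.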